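The compounds below may be only part of what the source reports. "The series", "measured", "known", "first", "only" and "open" are said of these compounds alone.

Series notes. Compound 1 `Cn1ccc2c(Oc3ccc(NC(=O)c4cn(-c5ccc(F)cc5)c5ccccc5c4=O)cc3F)ccnc21` gives 1460 nM in a functional assay on A549 cells (Homo sapiens) for inhibition, read by MTT assay, with a stated time of 72 h; a lower number here means a stronger inhibitor, a higher number a weaker inhibitor. Compound 2 `Cn1ccc2c(Oc3ccc(NC(=O)c4cn(-c5ccc(Cl)cc5)c5ccccc5c4=O)cc3F)ccnc21` gives 250 nM; the step of a 5.8-fold lower number from compound 1 to compound 2 (0.77 log units; beyond the scatter) comes with chloro in place of fluoro on an aromatic carbon. Compound 3 `O=C(Nc1ccc(Oc2ccnc3[nH]ccc23)c(F)c1)c1cn(-c2ccc(F)cc2)c2ccccc2c1=O` gives 290 nM; the step of a 5.0-fold lower number from compound 1 to compound 3 (0.70 log units; beyond the scatter) comes with hydrogen in place of methyl on an aromatic nitrogen, which is also how the core of compound 3 differs from the core of compound 1. Compound 2 and compound 3 sit within the scatter of each other.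

Compound 4 `O=C(Nc1ccc(Oc2ccnc3[nH]ccc23)c(F)c1)c1cn(-c2ccc(Cl)cc2)c2ccccc2c1=O` is not yet measured. It differs from compound 3 by chloro in place of fluoro on an aromatic carbon, the same change already seen from compound 1 to compound 2, at a place described in the same words, but here on the core of compound 3. Within the data shown here, with only one earlier instance of this change, and compound 3 already well below compound 1, the step is expected to point the same way but is taken with caution. For compound 4 the expected step is a 2.9-fold lower number from compound 3 to compound 4 (0.46 log units; beyond the scatter), resting on the earlier step of a 5.8-fold lower number from compound 1 to compound 2 (0.77 log units; beyond the scatter) and on compound 3 at 290 nM. Compound 4 is estimated at 100 nM in this assay, within 40 nM to 300 nM.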

Compound 4, half-maximal inhibitory concentration: 320 nM
For compound 4 the middle estimate is 3.2-fold (0.51 log units) below the measured one; measured number outside the range, above it.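

In this assay, the change from 4-fluorophenyl to 4-chlorophenyl gives a 1.1-fold higher number from compound 3 to compound 4 (0.04 log units; within the scatter) and does not repeat the earlier step on the core of compound 1: the same change on two cores in this assay, a 5.8-fold lower number (0.77 log units; beyond the scatter) from compound 1 to compound 2 and a 1.1-fold higher number (0.04 log units; within the scatter) from compound 3 to compound 4, 6.4-fold (0.81 log units) apart, beyond the scatter of two such steps.
Hydrogen in place of methyl on the aromatic nitrogen gives a 1.3-fold higher number from compound 2 to compound 4 (0.11 log units; within the scatter) with chloro present and also fails to repeat its earlier step, seen with fluoro present: the same change on two cores in this assay, a 5.0-fold lower number (0.70 log units; beyond the scatter) from compound 1 to compound 3 and a 1.3-fold higher number (0.11 log units; within the scatter) from compound 2 to compound 4, 6.4-fold (0.81 log units) apart, beyond the scatter of two such steps.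
These four compounds show that neither change carries unaltered from one core to the other in this series, but they form a single set in one assay and do not show which step would hold on a further core.

Still open, from the compounds shown here alone, is whether bromo, methyl, methoxy or plain hydrogen on that aromatic carbon would follow the step seen on the core of compound 1 or the one seen on the core of compound 3. Also open, going by these compounds, is how an ethyl group or a longer chain on the aromatic nitrogen would behave with fluoro or chloro present.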